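A few compounds are considered here, and "the series" means these few. Any claim that something is new, unique, unknown or untested is made for them only; others in the source may bear on it.

Compound 1 (`CC(=O)OC[C@H]1O[C@@H](n2cc(C3(O)C=CC(=O)C=C3)nn2)[C@H](OC(C)=O)[C@@H](OC(C)=O)[C@H]1OC(C)=O`) gives > 50000 nM in an ADME assay on MRC5 cells (Homo sapiens) for cytotoxicity, read by fluorescence and resazurin assay, with a stated time of 3 days (on this read-out higher numbers stand for an effect only at larger amounts of compound and lower numbers for an effect already at smaller amounts), and this is a limit of the assay, not a number. In this assay compound 2 (`O=C1C=CC(O)(c2cc3cnccc3n2S(=O)(=O)c2ccccc2)C=C1`) gives 41 nM as a true number. Compound 3 (`O=C1C=CC(O)(c2cc3ccccc3n2S(=O)(=O)c2ccc(CCC(=O)N3CCOCC3)cc2)C=C1`) gives 67 nM in this assay and so stands level with compound 2, since the two numbers lie within the usual scatter of each other.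

Compound 4 (`O=C1C=CC(O)(c2cc3ccccc3n2S(=O)(=O)c2ccc(CCC(=O)O)cc2)C=C1`) has not yet been measured. It differs from compound 3 in one place, on a carbonyl carbon, with hydroxy in place of morpholin-4-yl (hydroxy in place of morpholin-4-yl on a carbonyl carbon) so that the 2-((morpholin-4-yl)carbonyl)ethyl group becomes 2-carboxyethyl.

Going by the values given here, no two measured compounds differ in a single place, so no measured step shows what this swap does. The starting point is therefore compound 3 at 67 nM in this assay and a moderate rise in the number is expected from there, meaning that a larger amount of compound would be needed for the effect. The estimated step is a 3.7-fold higher number from compound 3 to compound 4 (0.57 log units; beyond the scatter) and it remains a judgement with wide margins. In this assay compound 4 is expected at 250 nM within an estimated range of 60 nM to 1500 nM for now.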

Compound 4, half-maximal effective concentration: 3300 nM
Compound 4: the middle estimate sits 13-fold (1.12 log units) below what was measured, outside the stated range (above it).
By their numbers in this assay, from the lowest: compounds 2 and 3 (each within the scatter of the next); then compound 4. At a limit, above all of these: compound 1.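

Going by these compounds alone, this is the first single change measured, and it shows that the group on this carbonyl carbon matters a great deal: putting hydroxy in place of morpholin-4-yl gives a 49-fold higher number from compound 3 to compound 4 (1.69 log units; beyond the scatter) in this assay. With the rest of the molecule unchanged, far more of compound 4 is needed for the same effect on the cells, so the far end of the 2-((morpholin-4-yl)carbonyl)ethyl group is not a silent place on this read-out. Only compound 1 stands at a limit of the assay, not at a true number, so the step between the other two compounds can be read in full: the limit of > 50000 nM in this assay, at which 1 of the 4 values shown sits.

The swap removes a whole six-membered ring and adds a single hydroxy, and these compounds cannot separate the loss of the morpholin-4-yl ring from the arrival of the hydroxy. A methyl ester or a dimethylamino group on the same carbonyl carbon could show which of the two counts, and a longer chain carrying the carboxylic acid could show whether the distance from the shared core matters.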